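Trifluoromethyl replaces methoxycarbonyl: expected tolerance on TZM cells

The source may report more compounds than this note shows. Statements on the series, on what has been measured and on what is new or still open speak of the compounds shown alone.

Compound 1 `Cc1cc(CO)cc(C)c1Oc1cc(Nc2ccc(C#N)cc2)c(N)cc1CO`: 15900 nM
Compound 2 `COC(=O)c1cc(N)c(Nc2ccc(C#N)cc2)cc1Oc1c(C)cc(/C=C/C#N)cc1C`: > 22800 nM

Of the compounds shown here, two have been measured in an ADME assay on TZM cells (Homo sapiens) for cytotoxicity, read by XTT assay, with a stated time of 4 days; a lower number here means that less compound is tolerated, a higher number that more compound is tolerated. Compound 1 gives 15900 nM. For compound 2 the assay returns only a limit, > 22800 nM, so compound 2 has no number of its own, only the statement that it sits at the limit of > 22800 nM in this assay, at which 1 of the 2 values shown sits. Among the measured compounds shown here, the two compounds differ in several places at once, so no single step between them can be read.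

Compound 3 `Cc1cc(/C=C/C#N)cc(C)c1Oc1cc(Nc2ccc(C#N)cc2)c(N)cc1C(F)(F)F` is the next compound to be measured in this assay. It differs from compound 2 in one place: trifluoromethyl in place of methoxycarbonyl on an aromatic carbon. For the measured compounds named here, no measured step of this kind is available. The expected step of an at least 1.1-fold lower number from compound 2 to compound 3 (0.05 log units; that floor lies within the scatter) is none beyond the usual scatter, since compound 2 stands at a limit and nothing measured points either way. Compound 3 is therefore estimated at 20000 nM, with a range from 8000 nM to 50000 nM.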

Compound 3, half-maximal cytotoxic concentration: 15000 nM
Compound 3: middle estimate off by 1.3-fold (0.12 log units), on the high side; measured number inside the range.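

In this assay, among the compounds shown here, putting trifluoromethyl in place of methoxycarbonyl on this aromatic carbon gives the only step that can be read at a single place: an at least 1.5-fold lower number from compound 2 to compound 3 (0.18 log units; that floor lies within the scatter). This position, para to a (4-cyanophenyl)amino group, now has a compound with a number of its own, as compound 3 gives 15000 nM. The size of the step remains bounded on one side only because compound 2 is measured only as a limit: the limit of > 22800 nM in this assay, at which 1 of the 3 values shown sits.

On these data alone, whether the true gap between compound 2 and compound 3 lies beyond the scatter remains open, and the step gives no direction that can be relied on. The compounds shown also leave open how an amine, a carboxylic acid or a longer chain on this aromatic carbon would behave in this assay.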